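A few compounds are considered here, and "the series" means these few. Any claim that something is new, unique, unknown or untested is made for them only; others in the source may bear on it.

Measured compounds in this set:

Compound 1 `COc1ccc(/C=N/NC(=O)Nc2ccc(Oc3ccnc(-c4nncn4CCN(C)C)c3)c(F)c2)c(OC)c1OC`: 3970 nM
Compound 2 `CN(C)CCn1cnnc1-c1cc(Oc2ccc(NC(=O)N/N=C/c3ccc(F)cc3F)cc2F)ccn1`: 960 nM
Compound 3 `CN(C)CCn1cnnc1-c1cc(Oc2ccc(NC(=O)N/N=C/c3ccc(Cl)cc3)cc2F)ccn1`: 530 nM

In a functional assay on HT-29 cells (Homo sapiens) for cytotoxicity, read by MTT assay, with a stated time of 72 h (a higher number here means a weaker inhibitor, a lower number a stronger inhibitor), compound 3 gives the lowest of the three numbers, separated from compound 1 beyond the scatter (a 7.5-fold lower number from compound 1 to compound 3 (0.87 log units; beyond the scatter)) but from compound 2 only within it (a 1.8-fold lower number from compound 2 to compound 3 (0.26 log units; within the scatter)). Compound 4 `CN(C)CCn1cnnc1-c1cc(Oc2ccc(NC(=O)N/N=C/c3ccc(O)c(F)c3)cc2F)ccn1` differs from compound 3 by 3-fluoro-4-hydroxyphenyl in place of 4-chlorophenyl on a carbon with a double bond to nitrogen. Among the compounds with values here, the steps that bear on this position are a 4.1-fold lower number from compound 1 to compound 2 (0.62 log units; beyond the scatter) and a 7.5-fold lower number from compound 1 to compound 3 (0.87 log units; beyond the scatter), both moving from the trimethoxyphenyl ring to a halogenated ring, while the step of a 1.8-fold lower number from compound 2 to compound 3 (0.26 log units; within the scatter) between two halogenated rings is small. Compound 4 keeps one fluorine but brings a hydroxyl, so a modest move back toward compound 1 is expected: a 1.7-fold higher number from compound 3 to compound 4 (0.23 log units; within the scatter). Compound 4 is therefore estimated at 900 nM, between 300 nM and 3000 nM.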

Compound 4, half-maximal inhibitory concentration: 3310 nM
Beside the measured number, compound 4's estimate is 3.7-fold (0.57 log units) below it; the whole stated range lies below it.
By their numbers in this assay, from the lowest: compounds 3 and 2 (each within the scatter of the next); then compounds 4 and 1 (each within the scatter of the next).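

In this assay, a fluorine on the ring does not by itself keep the number low: 3-fluoro-4-hydroxyphenyl gives a 6.2-fold higher number from compound 3 to compound 4 (0.80 log units; beyond the scatter) and a 3.4-fold higher number from compound 2 to compound 4 (0.54 log units; beyond the scatter). With a 1.2-fold lower number from compound 1 to compound 4 (0.08 log units; within the scatter), this ring does not separate from 2,3,4-trimethoxyphenyl, so a halogenated ring at this position does not always stand apart from the trimethoxyphenyl ring. Nothing measured here accounts for this result.

The compounds shown leave open whether the hydroxyl or the loss of the chlorine matters more. They also leave open whether an amine or a carboxylic acid in place of that hydroxyl would give a different number.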